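This account rests on a few compounds, and the source may have more. Where it says the series, first, only, none or still open, it means among the compounds named here.

Measured compounds: compound 1 `Cc1cnc(NC(=O)COc2ccc(/C=C3\SC(=O)NC3=O)cc2)s1`; compound 2 `CCCCC1=NC2(CCCC2)C(=O)N1C(=O)COc1ccc(/C=C2/SC(=O)NC2=O)cc1`; compound 3 `O=C(COc1ccc(/C=C2\SC(=O)NC2=O)cc1)Nc1cccc(C(F)(F)F)c1`.

In a functional assay on K562 cells (Homo sapiens) for cytotoxicity, read by sulforhodamine B assay, with a stated time of 48 h (on this read-out lower numbers stand for stronger inhibition of growth and higher numbers for weaker inhibition of growth), compound 1 gives 2240 nM. In this assay compound 3 gives 191 nM. For compound 2 this assay reports only a limit, < 100000 nM, which marks the bound of the assay rather than a number (the limit of < 100000 nM in this assay, at which 1 of the 3 values shown sits). Of the two numbers, compound 1 stands highest; the nearest, compound 3, is lower by a gap beyond the scatter.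

Compound 4 `O=C(COc1ccc(/C=C2\SC(=O)NC2=O)cc1)Nc1nc2ccccc2s1` differs from compound 1 by 1,3-benzothiazol-2-yl in place of 5-methyl-1,3-thiazol-2-yl on an amide-type nitrogen. Among the compounds with values here, no step between measured compounds is known for this change. The writer expects a small move toward stronger inhibition of growth, possibly within the scatter, as an estimated step of a 2.2-fold lower number from compound 1 to compound 4 (0.35 log units; beyond the scatter). Compound 4 is thus estimated at 1000 nM, in a range from 300 nM to 3500 nM.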

Compound 4, concentration for 50% growth inhibition: < 100000 nM
Compound 4 was reported as a limit (the forecaster's own chance of this, stated with the estimate: 10%); the middle value is on the limit's open side.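

In this assay compound 4 gives < 100000 nM as a limit and not a number, so no new step can be read from compound 1 to compound 4: the limit of < 100000 nM in this assay, at which 2 of the 4 values shown sit.

The compounds shown leave open how far 1,3-benzothiazol-2-yl in place of 5-methyl-1,3-thiazol-2-yl on an amide-type nitrogen moves growth inhibition.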